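Methyl on the Ring Carbon in a Quinoline Sulfonamide Series

The compounds below may be only part of what the source reports. "The series", "measured", "known", "first", "only" and "open" are said of these compounds alone.

The series begins with compound 1 `O=[N+]([O-])c1cc(C(F)(F)F)ccc1S(=O)(=O)Nc1cccc2cccnc12`, which in an assay on OCI-Ly3 cells for activation of NF-kappa-B inhibitor alpha (Homo sapiens), read by a luciferase reporter (on this read-out higher numbers stand for an effect only at larger amounts of compound and lower numbers for an effect already at smaller amounts), gives 3600 nM. Compound 2 `Cc1ccc2cccc(NS(=O)(=O)c3ccc(C(F)(F)F)cc3[N+](=O)[O-])c2n1` carries a change described as methyl in place of hydrogen on an aromatic carbon, and in this assay compound 2 gives 10000 nM. The step of a 2.8-fold higher number from compound 1 to compound 2 (0.44 log units; beyond the scatter) is therefore a move toward an effect only at larger amounts.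

Compound 3 `COc1cc(NS(=O)(=O)c2ccc(C)cc2[N+](=O)[O-])c2ncccc2c1` has a core that differs from that of compound 1 in a way that is not broken down here. In this assay compound 3 gives 6800 nM, which lies within the scatter of both compound 1 and compound 2.

Compound 4 `COc1cc(NS(=O)(=O)c2ccc(C)cc2[N+](=O)[O-])c2nc(C)ccc2c1` relates to compound 3 by a change described as methyl in place of hydrogen on an aromatic carbon. For the measured compounds named here, this is the same change as the one from compound 1 to compound 2, at the same place. Because the step of a 2.8-fold higher number from compound 1 to compound 2 (0.44 log units; beyond the scatter) lay beyond the scatter, compound 4 is expected to shift in the same direction, as a 2.5-fold higher number from compound 3 to compound 4 (0.40 log units; beyond the scatter). Going by the values given here, with only one earlier instance of this change, the expectation for compound 4 is 17000 nM, within a range from 8000 nM to 40000 nM.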

Compound 4, half-maximal effective concentration: > 10000 nM
Compound 4: no number, only a limit; the forecaster's own chance of this, stated with the estimate: 30%; the middle value is on the limit's open side.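

In this assay compound 4 gives > 10000 nM, which is a limit of the assay and not a number. On the core of compound 3, methyl in place of hydrogen on the aromatic carbon next to the ring nitrogen gives an at least 1.4-fold higher number from compound 3 to compound 4 (0.16 log units; that floor lies within the scatter), a floor that does not by itself establish a change beyond the usual scatter, and it cannot be said whether the change carries over with the same size: the same change on two cores in this assay, a 2.8-fold higher number (0.44 log units; beyond the scatter) from compound 1 to compound 2 and an at least 1.4-fold higher number (0.16 log units; that floor lies within the scatter) from compound 3 to compound 4; the limit leaves it open whether they differ The result therefore does not go against the rise seen on the core of compound 1, but it does not confirm it either, and two cores would be too few to set a rule for the series: the limit of > 10000 nM in this assay, at which 1 of the 4 values shown sits.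

The compounds shown leave open how far the number for compound 4 lies past its limit. They also leave open how an amine or a carboxylic acid in place of the methyl at this carbon would read on either core.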